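The compounds below may be only part of what the source reports. "The series", "measured", "known", "first", "only" and "open" are said of these compounds alone.

Among the measured compounds shown here, compound 1 `Cc1nnc(CN2CCCC2)n1-c1ccc(Cl)cc1Cc1ccccc1` stands at the high end of the three numbers known so far. In a functional assay on the whole organism (strain CF-1) for inhibition, with Mus musculus as the target (a higher number here means that more compound is needed for the effect, a lower number that less compound is needed), compound 1 gives 36 mg/kg. Compound 2 `Cc1nnc(CN(C)C)n1-c1ccc(Cl)cc1C(=O)c1ccccc1` gives 0.5 mg/kg in this assay, and compound 3 `CN(C)Cc1nn(CO)c(=O)n1-c1ccc(Cl)cc1C(=O)c1ccccc1Cl` gives 0.13 mg/kg there; both lie far below compound 1. Compound 4 `Cc1nnc(CN2CCCC2)n1-c1ccc(Cl)cc1C(=O)c1ccccc1Cl` has not yet been measured. It differs from compound 1 in one place: (2-chlorophenyl)carbonyl in place of benzyl on an aromatic carbon. For the measured compounds named here, no single-change step between measured compounds is available, so the expectation leans on compound 2 with 0.5 mg/kg and compound 3 with 0.13 mg/kg, both carrying a carbonyl link and both far lower than compound 1. A large downward step is expected, a 72-fold lower number from compound 1 to compound 4 (1.86 log units; beyond the scatter). Compound 4 is thus estimated at 0.5 mg/kg, within 0.1 mg/kg to 2.5 mg/kg.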

Compound 4, dose for half-maximal effect: 1.3 mg/kg
Compound 4: the middle estimate sits 2.6-fold (0.41 log units) below what was measured; the range from low to high includes it.
By their numbers in this assay, from the lowest: compound 3; then compound 2; then compound 4; then compound 1.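

With the rest of compound 1 kept, the exchange at this aromatic carbon gives a 28-fold lower number from compound 1 to compound 4 (1.44 log units; beyond the scatter) in this assay, so this place alone can shift the dose strongly. The exchange brings in a carbonyl and a chlorine together, and this single step cannot separate the two. What lies behind the drop is not shown by any measurement here. Whether the carbonyl or the chlorine accounts for the step remains open. So does how a 2-chlorobenzyl or a (2-fluorophenyl)carbonyl group would behave at this place.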